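A few compounds are considered here, and "the series" means these few. Any claim that something is new, unique, unknown or untested is made for them only; others in the source may bear on it.

Of the compounds shown here, three sharing one core have been tested in a functional assay on OVCAR-5 cells (Homo sapiens) for inhibition, read by sulforhodamine B assay, with a stated time of 48 h; on this read-out lower numbers stand for higher toxicity in this test and higher numbers for lower toxicity in this test. Compound 1 `CCOC(=O)[C@H](CCC(=O)O)NC(=O)c1ccc(CNc2nc3cc(N)cc(N)c3nc2-c2ccccc2)cc1` gives only a limit of the assay there, < 100000 nM. Compound 3 `CCOC(=O)[C@H](CCC(=O)O)NC(=O)c1ccc(Sc2nc3cc(N)cc(N)c3nc2-c2ccccc2)cc1` likewise gives only a limit, < 100000 nM. Among the compounds with values here, compound 2 `Nc1cc(N)c2nc(-c3ccccc3)c(NCc3ccc(Cl)c(Cl)c3)nc2c1` is the single compound with a number, giving 69200 nM in this assay, and it therefore stands alone among the three, since (the limit of < 100000 nM in this assay, at which 2 of the 3 values shown sit). Compound 4 `Nc1cc(N)c2nc(-c3ccccc3)c(NCc3ccc(F)cc3)nc2c1` has not yet been measured; it differs from compound 2 by 4-fluorophenyl in place of 3,4-dichlorophenyl on a saturated chain carbon bound to a nitrogen on an aromatic ring. Within the data shown here, no step between two measured compounds is available to show how large such a change might be. The expected step is a 1.2-fold higher number from compound 2 to compound 4 (0.06 log units; within the scatter), which would lie within the usual scatter. Compound 4 is accordingly estimated at 80000 nM, with a range from 30000 nM to 200000 nM.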

Compound 4, concentration lethal to 50% of the cells: < 100000 nM
Compound 4 gave a limit, no number; the forecaster's own chance of this, stated with the estimate: 40%; the middle value does not contradict the limit.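

No step from compound 2 to compound 4 can be read, because compound 4 sits at a limit of the assay: the limit of < 100000 nM in this assay, at which 3 of the 4 values shown sit.

On these data alone, whether 4-fluorophenyl in place of 3,4-dichlorophenyl changes the result in this assay at all, and by how much, stays open.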